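A few compounds are considered here, and "the series" means these few. Any claim that something is new, unique, unknown or untested is made for them only; others in the source may bear on it.

Measured so far:
Compound 2 `CCc1ccc(C(=O)Nc2cccc(NC(=O)COc3ccc4c(=O)ccoc4c3)c2)cc1`, 24 nM
Compound 1 `CC(=O)c1ccc(OCC(=O)Nc2cccc(NC(=O)c3ccc(N(C)C)cc3)c2)cc1F`, 98 nM

Both compounds were tested in an assay on isolated protein for inhibition of Rho-associated protein kinase 2 (Homo sapiens), read by scintillation counting, radiometric assay and 33P incorporation, with a stated time of 40 min, in the presence of a further agent that is not named here; a lower number here means a stronger inhibitor, a higher number a weaker inhibitor. Compound 2 gives the lowest number of the two, with compound 1 standing next to it at a higher number that lies beyond the usual scatter; the two differ in more than one place, so only their values can be compared. Compound 3 `Cc1nc(C(=O)Nc2cccc(NC(=O)COc3ccc4c(=O)ccoc4c3)c2)cs1` is not yet measured. It keeps the core of compound 2 and changes one group: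

2-methyl-1,3-thiazol-4-yl in place of 4-ethylphenyl on a carbonyl carbon

Going by the values given here, only two measured compounds are known and no single-point step between them, so the expectation for this change rests on the value of compound 2 alone. A modest loss of potency, beyond the scatter, is expected from the step of a 2.5-fold higher number from compound 2 to compound 3 (0.40 log units; beyond the scatter). Compound 3 is therefore estimated at 60 nM, in a range from 15 nM to 250 nM.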

Compound 3, half-maximal inhibitory concentration: 33 nM
Compound 3: the middle estimate sits 1.8-fold (0.26 log units) above what was measured, and the stated range covers the measured number.
By their numbers in this assay, from the lowest: compounds 2 and 3 (each within the scatter of the next); then compound 1.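

On the carbonyl carbon whose other neighbour is the amide-type nitrogen, 2-methyl-1,3-thiazol-4-yl can replace 4-ethylphenyl in this assay with no clear cost, as the change reads a 1.4-fold higher number from compound 2 to compound 3 (0.14 log units; within the scatter) and stays within the usual scatter. For this pair, then, a six-membered aromatic ring of carbon only and a five-membered aromatic ring with two hetero atoms give values that cannot be told apart, even though the entering group has fewer heavy atoms and brings two hydrogen-bond acceptors. Nothing available explains why the two groups give such similar values.

As far as these compounds go, it remains open how this position would respond to a very different group on the same carbonyl carbon, such as a saturated amine like piperidine, a carboxylic acid or a longer alkyl chain. Also open is whether the methyl group on the 2-methyl-1,3-thiazol-4-yl ring matters, since no compound shown lacks it.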